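A Phenol in Place of a Cyclic Amine

This account rests on a few compounds, and the source may have more. Where it says the series, first, only, none or still open, it means among the compounds named here.

Measured so far:
compound 1, `CCOC(=O)/C=C/[C@H](CC(C)C)NC(=O)[C@H](CO)NC(=O)[C@@H](NC(=O)OCc1ccccc1)C(C)C`: > 6 h
compound 2, `CCOC(=O)/C=C/[C@H](CC(C)C)NC(=O)[C@H](CO)NC(=O)[C@@H](NC(=O)C1=CCCNC1)C(C)C`: > 6 h

In an ADME assay for metabolic stability, in the presence of a further agent that is not named here (on this read-out lower numbers stand for a shorter-lived compound and higher numbers for a longer-lived compound), compound 1 gives > 6 h, which is a limit of the assay rather than a number. In this assay compound 2 gives > 6 h, also a limit. Compound 2 thus stands at the limit of > 6 h in this assay, at which 2 of the 2 values shown sit. Compound 3, `CCOC(=O)/C=C/[C@H](CC(C)C)NC(=O)[C@H](CO)NC(=O)[C@@H](NC(=O)c1cccc(O)c1C)C(C)C`, differs from compound 2 by a group of 8 heavy atoms (7 carbon, 1 oxygen; one six-membered aromatic ring of carbon only) in place of a group of 6 heavy atoms (5 carbon, 1 nitrogen; one six-membered non-aromatic ring with 1 hetero atom), on a carbonyl carbon. For the measured compounds named here, the one measured step that bears on this change is a step that the two limits leave unreadable from compound 1 to compound 2, and its size is hidden by the two limits. The expected step in this assay is a number no higher from compound 2 to compound 3 (the limit leaves the size open), none beyond the scatter. Compound 3 is therefore estimated at 6 h, with a range from 2.5 h to 12 h, and a limit may again be reported.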

Compound 3, half-life: > 6 h
Compound 3 ended at the assay's limit; the forecaster's own chance of this, stated with the estimate: 65%; the middle value sits exactly at the limit.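

For the compounds shown here, compound 1, compound 2 and compound 3 all stop at a limit in this assay, so no step among them can be read: the limit of > 6 h in this assay, at which 3 of the 3 values shown sit. From the compounds shown here alone, the true half-life of each compound, and whether the groups on the carbonyl carbon differ at all in this respect, stay open.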